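Dithiocarbamate-lactone anilides: extending the aryl substituent

This account rests on a few compounds, and the source may have more. Where it says the series, first, only, none or still open, it means among the compounds named here.

Measured compounds:
compound 1 `COc1ccc(NC(=O)CSC(=S)N[C@H]2CCOC2=O)cc1` — > 128000 nM
compound 2 `O=C(CSC(=S)N[C@H]1CCOC1=O)Nc1ccc(F)cc1` — 67100 nM
compound 3 `CCOC(=O)c1ccc(NC(=O)CSC(=S)N[C@H]2CCOC2=O)cc1` — 112000 nM

The three compounds share a core and differ only in the group on the anilide ring. In a functional assay on EC9706 cells (Homo sapiens) for cytotoxicity, read by MTT assay, with a stated time of 72 h (a lower number here means a stronger inhibitor, a higher number a weaker inhibitor), compound 1 reaches only a limit, (the limit of > 128000 nM in this assay, at which 1 of the 3 values shown sits), and gives no number. Compound 2 gives 67100 nM and compound 3 gives 112000 nM in this assay. Compound 3 stands at the highest of the two numbers, with compound 2 as the nearest, a 1.7-fold higher number from compound 2 to compound 3 (0.22 log units; within the scatter). For the measured compounds named here, the other steps are an at least 1.9-fold lower number from compound 1 to compound 2 (0.28 log units; that floor lies within the scatter) and an at least 1.1-fold lower number from compound 1 to compound 3 (0.05 log units; that floor lies within the scatter), both floors within the scatter, so none of the measured steps separates the compounds.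

Compound 4 `O=C(CSC(=S)N[C@H]1CCOC1=O)Nc1ccc(C(=O)/C=C/c2ccc(Cl)cc2)cc1` carries the change (2-(4-chlorophenyl)ethenyl in place of ethoxy on a carbonyl carbon). Going by the values given here, no measured step touches the carbonyl carbon of the ester; all three concern the aromatic substituent and all were small. The change in compound 4 is far larger in what enters than any measured step, so the measured steps give no direct guide to its direction; a step of some size in this assay is expected, and on balance toward a lower number. Compound 4 is therefore expected at 25000 nM, between 4000 nM and 110000 nM, which corresponds to an estimated step of a 4.5-fold lower number from compound 3 to compound 4 (0.65 log units; beyond the scatter).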

Compound 4, half-maximal inhibitory concentration: 38900 nM
The estimate for compound 4 lay 1.6-fold (0.19 log units) below the measured number, within the range that was stated.
By their numbers in this assay, from the lowest: compounds 4, 2 and 3 (each within the scatter of the next, the first and the last beyond it). At a limit, above all of these: compound 1.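

In this assay, putting 2-(4-chlorophenyl)ethenyl in place of ethoxy on a carbonyl carbon whose other neighbour is an aromatic carbon gives a 2.9-fold lower number from compound 3 to compound 4 (0.46 log units; beyond the scatter), a modest step and the only one in the series printed as beyond the scatter. The carbonyl carbon therefore responds to substitution in a way that the exchanges on the aromatic carbon, among methoxy, fluoro and ethoxycarbonyl, did not show, and the ethoxy can be given up there with no rise in the number. Nothing measured here bears on why this step occurs.

The single change brings in a chlorine, a six-membered aromatic ring and a double bond together, so the compounds shown leave open which of these carries the step, a question that an unsubstituted 2-phenylethenyl group or a saturated 2-(4-chlorophenyl)ethyl chain on the same carbonyl carbon would address. Also open, on these data alone, is how far the step depends on a carbon substituent at that place, since an amine or a carboxylic acid there would test a different kind of group on the shared core.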